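Series notes: methyl-to-trifluoromethyl swap on the benzyl arm

The source may hold more compounds than are shown below. What is called first, only, known or untested is meant among the compounds shown, and "the series" means these compounds.

Compound 1, `Cc1ccc(CSc2nc3nc(C)cc(Nc4cc(-c5ccccc5)[nH]n4)n3n2)cc1`: in a functional assay on PC-9 cells (Homo sapiens) for inhibition, read by MTT assay, with a stated time of 72 h (on this read-out lower numbers stand for stronger inhibition and higher numbers for weaker inhibition), compound 1 gives 7310 nM.
Compound 2, `Cc1cc(Nc2cc(-c3ccccc3)[nH]n2)n2nc(SCc3ccc(C(F)(F)F)cc3)nc2n1`: in this assay compound 2 gives 4240 nM.
Compound 3, `Cc1ccc(Cn2ccc(Nc3cc(C)nc4nc(SCc5ccc(Br)cc5)nn34)n2)cc1`: in this assay compound 3 reaches only a limit of the assay, > 50000 nM.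

The step from compound 1 to compound 2 is a single change, (trifluoromethyl in place of methyl on an aromatic carbon), and it gave a 1.7-fold lower number from compound 1 to compound 2 (0.24 log units; within the scatter). The pair compound 3 and compound 4 carries the same change, (trifluoromethyl in place of methyl on an aromatic carbon), at the same place. The difference between the core of compound 1 and the core of compound 3 is not broken down here. Compound 4 is `Cc1cc(Nc2ccn(Cc3ccc(C(F)(F)F)cc3)n2)n2nc(SCc3ccc(Br)cc3)nc2n1` and has not been measured in this assay.

Because the earlier step stayed within the scatter, and because compound 3 sits at the limit of > 50000 nM in this assay, at which 1 of the 3 values shown sits, the step from compound 3 to compound 4 is expected to be small, a step that the limit leaves unreadable from compound 3 to compound 4. Compound 4 is therefore estimated at 60000 nM in this assay, with a range from 20000 nM to 200000 nM, and most likely only a limit will again be reported.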

Compound 4, half-maximal inhibitory concentration: 5580 nM
Estimate against measurement, compound 4: 11-fold (1.03 log units) above; the whole stated range lies above it.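

Working notes on the change from 4-methylbenzyl to 4-(trifluoromethyl)benzyl: on the core of compound 3, this swap in this assay gives an at least 8.9-fold lower number from compound 3 to compound 4 (0.95 log units; beyond the scatter). The value of compound 3 is a limit of the assay, > 50000 nM, so the full size of this step stays unfixed. The size of the step does not carry over unchanged from one core to the other, although two cores neither establish a rule for the series nor show why the steps differ: the same change on two cores in this assay, a 1.7-fold lower number (0.24 log units; within the scatter) from compound 1 to compound 2 and an at least 8.9-fold lower number (0.95 log units; beyond the scatter) from compound 3 to compound 4, at least 5.1-fold (0.71 log units) apart, beyond the scatter of two such steps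

On these data alone, the difference between the core of compound 1 and the core of compound 3 is not broken down, so it remains open which part of it goes with the gap between the two steps. Also open, as far as these compounds go, is how a nitrile, a methoxy group or a carboxylic acid in place of the trifluoromethyl would read on either core.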